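The source may report more compounds than this note shows. Statements on the series, on what has been measured and on what is new or still open speak of the compounds shown alone.

In a functional assay on SMMC-7721 cells (Homo sapiens) for cytotoxicity, read by MTT assay, with a stated time of 24 h (on this read-out higher numbers stand for weaker inhibition and lower numbers for stronger inhibition), the measured compounds stand as follows:

compound 1 `O=C1/C(=C/c2cccnc2)CN(S(=O)(=O)c2ccc(Cl)cc2)C/C1=C\c1ccccc1F`, 16100 nM
compound 2 `O=C1/C(=C/c2cccnc2)CN(S(=O)(=O)c2ccc(Br)cc2)C/C1=C\c1ccccc1F`, 9100 nM
compound 3 `O=C1/C(=C/c2cccnc2)CN(S(=O)(=O)c2ccc(Cl)cc2)C/C1=C\c1ccccc1C(F)(F)F`, 4880 nM

From compound 1 to compound 2 the change is bromo in place of chloro on an aromatic carbon, and it made a 1.8-fold lower number from compound 1 to compound 2 (0.25 log units; within the scatter). The cores of compound 1 and compound 3 differ by trifluoromethyl in place of fluoro on an aromatic carbon, a change that made a 3.3-fold lower number from compound 1 to compound 3 (0.52 log units; beyond the scatter). Compound 4 `O=C1/C(=C/c2cccnc2)CN(S(=O)(=O)c2ccc(Br)cc2)C/C1=C\c1ccccc1C(F)(F)F` carries the same change as compound 2, now on the core of compound 3: bromo in place of chloro on an aromatic carbon. Going by the values given here, the place of the change is the same in both pairs, so the one measured step is the only guide, and it has been seen once only. Because a 1.8-fold lower number from compound 1 to compound 2 (0.25 log units; within the scatter) lay within the scatter, the expected step is a 1.5-fold lower number from compound 3 to compound 4 (0.18 log units; within the scatter). For compound 4 the estimate in this assay is 3200 nM, expected to fall between 1500 nM and 7000 nM.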

Compound 4, half-maximal inhibitory concentration: 5760 nM
The estimate for compound 4 lay 1.8-fold (0.26 log units) below the measured number; measured number inside the range.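

In this assay, bromo in place of chloro gives a 1.2-fold higher number from compound 3 to compound 4 (0.07 log units; within the scatter), and the two cores cannot be told apart for this change: the same change on two cores in this assay, a 1.8-fold lower number (0.25 log units; within the scatter) from compound 1 to compound 2 and a 1.2-fold higher number (0.07 log units; within the scatter) from compound 3 to compound 4, 2.1-fold (0.32 log units) apart, within the scatter of two such steps. Trifluoromethyl in place of fluoro gives a 1.6-fold lower number from compound 2 to compound 4 (0.20 log units; within the scatter), and again the two cores cannot be told apart: the same change on two cores in this assay, a 3.3-fold lower number (0.52 log units; beyond the scatter) from compound 1 to compound 3 and a 1.6-fold lower number (0.20 log units; within the scatter) from compound 2 to compound 4, 2.1-fold (0.32 log units) apart, within the scatter of two such steps. Going by these compounds alone, this shows that neither change differs measurably between the two cores, but with only two pairs per change it does not show that either step carries over reliably, and the trifluoromethyl step lies beyond the scatter on only one core, a 3.3-fold lower number from compound 1 to compound 3 (0.52 log units; beyond the scatter).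

Open, from the compounds shown here alone, is whether a methoxy or nitrile group in place of the bromo or chloro would follow the same course on both cores. Also open, going by these compounds, is whether these steps hold in other cell lines.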